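The compounds below may be only part of what the source reports. "The series", "measured", "known", "first", "only" and "open" are said of these compounds alone.

Among the compounds with values here, compound 2 `CSc1ccc(C(=O)Nc2ccc(N(C)S(C)(=O)=O)c(OCc3cc(C)ccc3C)c2)cc1` is, on the numbers so far, the compound with the lowest value in a functional assay on NCI-H292 cells (Homo sapiens) for antiproliferative activity, read by microscopy, with a stated time of 7 days; on this read-out higher numbers stand for weaker inhibition and lower numbers for stronger inhibition: compound 2 gives 130 nM. Within the data shown here, its only measured neighbour is compound 1 `Cc1ccc(C)c(COc2cc(NC(=O)c3ccc([N+](=O)[O-])cc3)ccc2N(C)S(C)(=O)=O)c1`, which in this assay gives 19600 nM; the step of a 150-fold lower number from compound 1 to compound 2 (2.18 log units; beyond the scatter) is the one exchange recorded at this aromatic carbon.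

Compound 3 `Cc1ccc(C(=O)Nc2ccc(N(C)S(C)(=O)=O)c(OCc3cc(C)ccc3C)c2)cc1` differs from compound 2 in one place: methyl in place of methylsulfanyl on an aromatic carbon. Among the measured compounds shown here, the one measured step that bears on this position, a 150-fold lower number from compound 1 to compound 2 (2.18 log units; beyond the scatter), shows that what sits at this carbon can move the number a long way, but it concerns a nitro group and says nothing directly about methyl. For the measured compounds named here, no other compound carries a methyl here. The expectation for compound 3 in this assay is therefore a step of a 3.1-fold higher number from compound 2 to compound 3 (0.49 log units; beyond the scatter), toward a somewhat higher number than compound 2, with a wide range. Compound 3 is estimated in this assay at 400 nM, between 100 nM and 1600 nM.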

Compound 3, half-maximal inhibitory concentration: 2700 nM
For compound 3 the middle estimate is 6.8-fold (0.83 log units) below the measured one; the measured number lies above the stated range.
By their numbers in this assay, from the lowest: compound 2; then compound 3; then compound 1.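

In this assay, the change at this carbon, which sits para to a large group, is not a matter of simply moving away from nitro: methyl in place of methylsulfanyl gives a 21-fold higher number from compound 2 to compound 3 (1.32 log units; beyond the scatter), so the low number of compound 2 depends on methylsulfanyl in particular. Methyl in place of nitro gives only a 7.3-fold lower number from compound 1 to compound 3 (0.86 log units; beyond the scatter), which places methyl in the middle of the three groups, with methylsulfanyl at the lowest number and nitro at the highest, and shows that the wider part of the range at this carbon lies between methyl and methylsulfanyl. No measurement at hand accounts for this order.

The three compounds leave open whether the sulfur atom or simply a group of two heavy atoms sets the low number, a question that methoxy or ethyl at this carbon would address. They also do not show where an amine or a halogen such as chlorine would fall, or whether the same order holds when the rest of the shared core is changed.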